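A Chloro for Fluoro Swap on Compound 2

The compounds below may be only part of what the source reports. "The series", "measured", "known", "first", "only" and "open" are said of these compounds alone.

In a functional assay on A-431 cells (Homo sapiens) for antiproliferative activity, read by sulforhodamine B assay, with a stated time of 72 h (a lower number here means a stronger inhibitor, a higher number a weaker inhibitor), compound 1 `C=C1CC(CBr)(c2ccc(OC)cc2)OC1=O` gives 4200 nM while compound 2 `C=C1CC(CBr)(c2ccc(F)cc2)OC1=O` gives 800 nM and holds the lower of the two numbers. Compound 3 `C=C1CC(CBr)(c2ccc(Cl)cc2)OC1=O` carries chloro in place of fluoro on an aromatic carbon relative to compound 2, with chloro in place of fluoro on an aromatic carbon. Among the compounds with values here, the one measured step, a 5.3-fold lower number from compound 1 to compound 2 (0.72 log units; beyond the scatter) for fluoro in place of methoxy on an aromatic carbon, is modest and involves a different departing group, so it sets no direct size for this change. A step within the scatter is therefore expected in this assay with no firm direction, and a 1.1-fold lower number from compound 2 to compound 3 (0.06 log units; within the scatter) is the estimated step. Compound 3 is estimated at 700 nM with an expected range from 300 nM to 1800 nM as its likely reading.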

Compound 3, half-maximal inhibitory concentration: 1100 nM
Compound 3: the middle estimate sits 1.6-fold (0.20 log units) below what was measured, and the stated range covers the measured number.
By their numbers in this assay, from the lowest: compounds 2 and 3 (each within the scatter of the next); then compound 1.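

In this assay, exchanging one halogen for the other on this aromatic carbon leaves the reading within the scatter (a 1.4-fold higher number from compound 2 to compound 3 (0.14 log units; within the scatter)). Chloro also reads apart from methoxy at this place, beyond the scatter (a 3.8-fold lower number from compound 1 to compound 3 (0.58 log units; beyond the scatter)), so compound 2 and compound 3 both separate from compound 1, while fluoro and chloro cannot be told apart here. No measurement shown explains these readings.

From the compounds shown here alone, whether an amine or a carboxylic acid on this carbon would read with the halogens or with methoxy remains open. So does the effect of any change elsewhere on the shared core.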